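Arylpiperazine swap on a dihydropyrimidinone urea

This account rests on a few compounds, and the source may have more. Where it says the series, first, only, none or still open, it means among the compounds named here.

Compounds measured so far:
Compound 1 `COCC1=C(C(=O)OC)C(c2cc(F)c(F)cc2F)N(C(=O)NCCCN2CCN(c3ccccc3C(N)=O)CC2)C(=O)N1`, 190 nM
Compound 2 `COC(=O)C1=C(C)NC(=O)N(C(=O)NCCCN2CCN(c3ccc(Cl)cc3)CC2)C1c1ccc(F)c(F)c1`, 52 nM
Compound 3 `CC(=O)C1=C(C)NC(=O)N(C(=O)NCCCN2CCN(c3ccccc3C(N)=O)CC2)C1c1ccc(F)c(F)c1`, 290 nM

The three compounds were tested in an assay on liver for binding affinity to Alpha-1D adrenergic receptor (Homo sapiens), using microsomes; a higher number here means a weaker inhibitor, a lower number a stronger inhibitor. Among them compound 2 has the lowest number, and its gaps to compound 1 and to compound 3 both lie beyond the usual scatter of this assay, so compound 2 is the strongest binder of the three. Compound 1 and compound 3 lie closer to each other.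

Compound 4 `COC(=O)C1=C(C)NC(=O)N(C(=O)NCCCN2CCN(c3ccccc3OC)CC2)C1c1ccc(F)c(F)c1` has not yet been measured. It keeps the whole of compound 2 apart from one change: 2-methoxyphenyl in place of 4-chlorophenyl on an amine nitrogen in a ring

For the measured compounds named here, no pair of measured compounds differs in this one place, so the size of this step is not known from these data. The account expects the step from compound 2 to compound 4 in this assay to be a modest move toward a lower number, estimated as a 2.1-fold lower number from compound 2 to compound 4 (0.32 log units; beyond the scatter), though a result within the scatter would not surprise. Compound 4 is therefore estimated at 25 nM, with a likely range from 6 nM to 100 nM.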

Compound 4, inhibition constant: 31 nM
For compound 4 the middle estimate is 1.2-fold (0.09 log units) below the measured one; low and high end bracket the measured number.
By their numbers in this assay, from the lowest: compounds 4 and 2 (each within the scatter of the next); then compounds 1 and 3 (each within the scatter of the next).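

In this assay, for the compounds shown here, the first readable step at this position is a 1.7-fold lower number from compound 2 to compound 4 (0.22 log units; within the scatter), so 2-methoxyphenyl and 4-chlorophenyl on the amine nitrogen in the ring cannot be told apart here. The position thus accepts this exchange without a measurable shift, even though the entering group carries a hydrogen-bond acceptor that the leaving group lacks. Nothing available offers a reason for this result.

The compounds shown leave open how 2-chlorophenyl or 4-methoxyphenyl would read at this place, which would separate the identity of the group from where it sits on the phenyl ring. Also open, going by these compounds, is whether a plain phenyl or a pyridine ring would stay in this range, and how the amide-bearing phenyl of compound 1 and compound 3 would compare on the core of compound 2.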